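Taking One Chloro from the Dichlorophenyl Compound

This account rests on a few compounds, and the source may have more. Where it says the series, first, only, none or still open, it means among the compounds named here.

In an ADME assay on MRC5 cells (Homo sapiens) for cytotoxicity, read by fluorescence and resazurin assay, with a stated time of 3 days (a lower number here means a stronger inhibitor, a higher number a weaker inhibitor), compound 1 `Cc1cn(C2CCN(Cc3cccc(Oc4ccc(Cl)cc4)c3)CC2)c(=O)[nH]c1=O` gives 25100 nM. For compound 2 `Cc1cn(C2CCN(Cc3cccc(Oc4ccccn4)c3)CC2)c(=O)[nH]c1=O` the assay returns a limit, > 64000 nM. For the measured compounds named here, compound 3 `Cc1cn(C2CCN(Cc3cccc(Oc4ccc(Cl)c(Cl)c4)c3)CC2)c(=O)[nH]c1=O` gives 6100 nM, the lowest number of the series so far, and its steps to both other compounds lie beyond the scatter.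

Compound 4 `Cc1cn(C2CCN(Cc3cccc(Oc4cccc(Cl)c4)c3)CC2)c(=O)[nH]c1=O` differs from compound 3 as follows: hydrogen in place of chloro on an aromatic carbon. This is hydrogen in place of chloro on an aromatic carbon, turning 3,4-dichlorophenyl into 3-chlorophenyl.

The closest measured change is a 4.1-fold lower number from compound 1 to compound 3 (0.61 log units; beyond the scatter), where chloro replaced hydrogen. That is the opposite kind of change, and at a different carbon. The step of an at least 10-fold lower number from compound 2 to compound 3 (1.02 log units; beyond the scatter) is larger, but it exchanges a whole pyridin-2-yl group and starts from a limit, so it says less here.

A modest rise in this assay is therefore expected, similar in size to the step that added a chloro. The expected change is a 3.1-fold higher number from compound 3 to compound 4 (0.49 log units; beyond the scatter). For compound 4 the estimated value is 19000 nM, within an expected range of 8000 nM to 45000 nM.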

Compound 4, half-maximal inhibitory concentration: 21000 nM
For compound 4 the middle estimate is 1.1-fold (0.04 log units) below the measured one; low and high end bracket the measured number.
By their numbers in this assay, from the lowest: compound 3; then compounds 4 and 1 (each within the scatter of the next). At a limit, above all of these: compound 2.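

In this assay, the change gives a 3.4-fold higher number from compound 3 to compound 4 (0.54 log units; beyond the scatter), so the lower number of compound 3 is lost once the chloro is gone and only the 3-chlorophenyl group remains. With a single chloro on the ring, its place makes no readable difference: 3-chlorophenyl in place of 4-chlorophenyl gives a 1.2-fold lower number from compound 1 to compound 4 (0.08 log units; within the scatter), and among these compounds only the 3,4-dichlorophenyl group stands apart. The value of compound 2 is a limit, and 3-chlorophenyl in place of pyridin-2-yl gives an at least 3.0-fold lower number from compound 2 to compound 4 (0.48 log units; beyond the scatter), which is a bound and not a size: the limit of > 64000 nM in this assay, at which 1 of the 4 values shown sits.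

The compounds shown leave open how a plain phenyl, with no chloro at all, would read in this assay. They also leave open whether a fluoro, methyl or methoxy group on these carbons would behave as chloro does.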